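From 4-chlorobenzyl to 4-fluorobenzyl: cytotoxicity notes

The source may hold more compounds than are shown below. What is called first, only, known or untested is meant among the compounds shown, and "the series" means these compounds.

Values from a functional assay on MT4 cells (Homo sapiens) for cytotoxicity, read by MTT assay (on this read-out lower numbers stand for higher toxicity in this test and higher numbers for lower toxicity in this test), are as follows.
- compound 1 (`Cc1c(O)nc(SCc2ccc(Cl)cc2)nc1Cc1c(Cl)cccc1Cl`) gives > 59000 nM (a limit)
- compound 2 (`COc1ccc(CCCSc2nc(O)c(C)c(Cc3c(Cl)cccc3Cl)n2)cc1`) gives 1000 nM
- compound 3 (`COc1ccc(CS(=O)(=O)c2nc(O)c(C)c(Cc3c(Cl)cccc3Cl)n2)cc1`) gives 2800 nM

Compound 1 stands at a limit and not at a number, with the limit of > 59000 nM in this assay, at which 1 of the 3 values shown sits. Compound 2 and compound 3 give numbers, but no change in one place links either of them to compound 1.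

Compound 4 (`Cc1c(O)nc(SCc2ccc(F)cc2)nc1Cc1c(Cl)cccc1Cl`) carries fluoro in place of chloro on an aromatic carbon, para to a large group, so that 4-chlorobenzyl becomes 4-fluorobenzyl: fluoro in place of chloro on an aromatic carbon. For the measured compounds named here, no measured step bears on this change, so no shift beyond the usual scatter is expected in this assay, and no direction is favoured. The expected move is a step that the limit leaves unreadable from compound 1 to compound 4. This expectation rests on compound 1, whose limit is > 59000 nM. A result reported only as a limit is again expected to be quite possible. Compound 4 is estimated at 60000 nM, with an expected range from 20000 nM to 180000 nM.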

Compound 4, half-maximal cytotoxic concentration: > 61000 nM
Compound 4 was reported as a limit; the forecaster's own chance of this, stated with the estimate: 55%; middle value at least 1.0-fold (0.00 log units) away from the limit.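

In this assay, for the compounds shown here, compound 1 and compound 4 are both reported only as limits, so no step between them can be read. The compounds shown leave open whether fluoro in place of chloro on an aromatic carbon shifts the half-maximal cytotoxic concentration at all.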